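Catechol extension of a chloro-hydroxyphenyl enol series

The source may report more compounds than this note shows. Statements on the series, on what has been measured and on what is new or still open speak of the compounds shown alone.

Measured so far:
compound 1 `O=C(/C=C(O)/C=C/c1cccc(O)c1)c1cc(Cl)ccc1O` — 36400 nM
compound 2 `COc1cccc(/C=C2\CCC/C(=C\c3ccccc3)C2=O)c1OC` — "not determined" (no result reported)
compound 3 `O=C1/C(=C/c2ccccc2)CCC/C1=C\c1ccccc1Br` — "not determined" (no result reported)

Within the data shown here, in an assay on isolated protein for inhibition of Alpha glucosidase (Homo sapiens), with stated times of 5 min and 15 min (on this read-out higher numbers stand for weaker inhibition and lower numbers for stronger inhibition), compound 1 gives 36400 nM, and this is the only number available. Among the measured compounds shown here, for compound 2 this assay reports "not determined" (no result reported) and for compound 3 it reports "not determined" (no result reported), so neither offers a comparison point, and no step between measured compounds can be drawn. Compound 1 therefore stands alone as the reference.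

The next compound, compound 4 `O=C(/C=C(O)/C=C/c1ccc(O)c(O)c1)c1cc(Cl)ccc1O`, differs from compound 1 by hydroxy in place of hydrogen on an aromatic carbon. For the measured compounds named here, with no measured step of this kind, the expectation rests on the structural change alone: a modest shift toward stronger inhibition is expected, of a size at or just beyond the usual scatter, so the estimated step of a 2.4-fold lower number from compound 1 to compound 4 (0.39 log units; beyond the scatter) is small but directional. For compound 4 the estimate in this assay is 15000 nM, with a range from 5000 nM to 45000 nM.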

Compound 4, half-maximal inhibitory concentration: 15100 nM
Estimate against measurement, compound 4: 1.0-fold (0.00 log units) below, and the stated range covers the measured number.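

In this assay, the series gains its first measured step: hydroxy in place of hydrogen on an aromatic carbon gives a 2.4-fold lower number from compound 1 to compound 4 (0.38 log units; beyond the scatter). This shows that the position ortho to a hydroxy group and para to a large group can take a further hydroxy with a change toward stronger inhibition, which compound 1 alone could not show. The finding rests on one pair of compounds, and nothing at hand bears on the reason for the shift.

Whether the shift depends on the ortho hydroxy group remains open, as the compounds shown do not separate the two groups. It is also unknown whether an amine or a carboxylic acid at this position would shift the number in the same direction as hydroxy.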